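Lengthening the Alkyl Chain on the Thiourea Nitrogen

The source may report more compounds than this note shows. Statements on the series, on what has been measured and on what is new or still open speak of the compounds shown alone.

Compound 1 `FC(F)(F)c1cccc(NC(=S)Nc2ccccc2)c1` gives 39000 nM in an ADME assay on Vero 76 cells (Chlorocebus sabaeus) for cytotoxicity, read by crystal violet staining, with a stated time of 96 h; on this read-out lower numbers stand for higher toxicity in this test and higher numbers for lower toxicity in this test.
Compound 2 `CCNC(=S)Nc1cccc(C(F)(F)F)c1` gives > 100000 nM in this assay.

For compound 2 the value in this assay is a limit of the assay and not a number; it sits at the limit of > 100000 nM in this assay, at which 1 of the 2 values shown sits. Going by the values given here, the one measured step, an at least 2.5-fold higher number from compound 1 to compound 2 (0.40 log units; beyond the scatter), moved from a number up to that limit. Compound 3 `CSCCCNC(=S)Nc1cccc(C(F)(F)F)c1` keeps the core of compound 2 and differs only by (methylsulfanyl)methyl in place of hydrogen on a saturated chain carbon, two bonds along the chain from an amide-type nitrogen. Among the compounds with values here, no measured step covers this particular change, so there is no direct guide to its size. Since compound 2 already rests at the limit, any step beyond the scatter can only be seen if the number falls. Compound 3 is expected to remain near the limit, with an estimated a number no higher from compound 2 to compound 3 (the limit leaves the size open), giving an estimate of 100000 nM in this assay, with a range from 40000 nM to 250000 nM.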

Compound 3, half-maximal cytotoxic concentration: > 100000 nM
Compound 3 ended at the assay's limit; the forecaster's own chance of this, stated with the estimate: 55%; the middle value sits exactly at the limit.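

In this assay compound 3 gives > 100000 nM as a limit of the assay and not a number. Replacing the phenyl on the amide-type nitrogen with 3-(methylsulfanyl)propyl gives an at least 2.5-fold higher number from compound 1 to compound 3 (0.40 log units; beyond the scatter) and so shows that ethyl, as in compound 2, is not the only chain here that stands clear of the number for the phenyl compound, even with a sulfur atom added. The step from compound 2 to compound 3 cannot be read, so any effect of the added (methylsulfanyl)methyl stays hidden: the limit of > 100000 nM in this assay, at which 2 of the 3 values shown sit.

From the compounds shown here alone, how compound 2 and compound 3 would compare without the limit remains open. Also open, going by these compounds, is whether a chain carrying an amine or a carboxylic acid in place of the methylsulfanyl group, or a longer alkyl chain, would bring the number down from the limit.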